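Removing the Core Methyl from a Growth Inhibitor

A few compounds are considered here, and "the series" means these few. Any claim that something is new, unique, unknown or untested is made for them only; others in the source may bear on it.

Measured compounds:
compound 1, `Cc1cnc2nc(-c3ccc4ccccc4c3)cc(O)c2c1`: 550 nM
compound 2, `Cc1cccc(-c2cc(O)c3ccc(C)nc3n2)c1`: 60.3 nM

Of the compounds shown here, two that share a core have been tested in a functional assay on SF-295 cells (Homo sapiens) for antiproliferative activity; a lower number here means a stronger inhibitor of growth, a higher number a weaker inhibitor of growth. Compound 1 gives 550 nM, which is the higher of the two numbers. Compound 2 gives 60.3 nM, a lower number, and the gap between the two lies beyond the usual scatter. Compound 2 differs from compound 1 in more than one place, so nothing is drawn from the pair about any single change.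

Compound 3, `Oc1cc(-c2ccc3ccccc3c2)nc2ncccc12`, has not yet been measured. It differs from compound 1 in one place: hydrogen in place of methyl on an aromatic carbon. The methyl that leaves sits on an aromatic carbon of a six-membered aromatic ring with 1 nitrogen, part of a fused or bridged system of two rings, two atoms from the ring nitrogen. Within the data shown here, no measured pair in this set isolates such a change, so the size and direction of the step rest on general experience with the loss of a single methyl. A small step is expected, most likely none beyond the scatter, with a slight lean toward a weaker inhibitor of growth. For compound 3 the expected step is a 1.4-fold higher number from compound 1 to compound 3 (0.13 log units; within the scatter). Compound 3 is therefore estimated at 750 nM, within a range of 250 nM to 2500 nM.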

Compound 3, concentration for 50% growth inhibition: 9120 nM
Compound 3: the middle estimate sits 12-fold (1.08 log units) below what was measured; the whole stated range lies below it.
By their numbers in this assay, from the lowest: compound 2; then compound 1; then compound 3.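

In this assay, replacing the methyl with hydrogen on this aromatic carbon, two atoms from the ring nitrogen, gives a 17-fold higher number from compound 1 to compound 3 (1.22 log units; beyond the scatter), so this one small change produces a large loss in growth inhibition. Among these compounds, this is the first pair in the set that isolates a single change, and it shows that, at least with the rest of compound 1 held fixed, this position is far from indifferent to the loss of one carbon atom. Nothing available accounts for a step of this size from so small a change, and the result records only that it occurred.

On these data alone, it remains open whether an ethyl group, a methoxy group or a chlorine atom on this same carbon would keep, improve or lose the growth inhibition seen with the methyl, which would show how much of the step depends on the methyl itself. Among the compounds shown here, it is also open whether removing the methyl would cost as much on a core bearing a different aromatic group from the one in compound 1, or in cells other than those of this single assay.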